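The source may report more compounds than this note shows. Statements on the series, on what has been measured and on what is new or still open speak of the compounds shown alone.

Notes on the sulfone series. In a functional assay on CHO.K1 cells for antagonist activity at prostaglandin D2 receptor 2 (Homo sapiens), read by GTPgammaS binding, with a stated time of 1 h (a higher number here means a weaker inhibitor, a lower number a stronger inhibitor), compound 1 `Cc1c(Cc2ccccc2S(=O)(=O)c2cccc(Cl)c2)c2c(n1CC(=O)O)CCNC2=O` gives 4 nM. In this assay compound 2 `Cc1c(Cc2ccccc2S(=O)(=O)c2ccc(F)cc2)c2c(n1CC(=O)O)CCNC2=O` gives 3.3 nM. In this assay compound 3 `Cc1c(Cc2ccccc2S(=O)(=O)c2ccc(OC(F)(F)F)cc2)c2c(n1CC(=O)O)CCNC2=O` gives 6.6 nM, the highest of the three numbers, though its gaps to the others are within the scatter: a 1.7-fold higher number from compound 1 to compound 3 (0.22 log units; within the scatter) and a 2.0-fold higher number from compound 2 to compound 3 (0.30 log units; within the scatter). Compound 4 `Cc1c(Cc2ccccc2S(=O)(=O)C2CCCCC2)c2c(n1CC(=O)O)CCNC2=O` differs from compound 3 as follows: cyclohexyl in place of 4-(trifluoromethoxy)phenyl on a sulfonyl sulfur. Among the compounds with values here, the measured steps all swap one aryl group for another on the sulfonyl sulfur (a 1.2-fold lower number from compound 1 to compound 2 (0.08 log units; within the scatter), a 1.7-fold higher number from compound 1 to compound 3 (0.22 log units; within the scatter), a 2.0-fold higher number from compound 2 to compound 3 (0.30 log units; within the scatter)) and none reach beyond the scatter; no measured step replaces the aryl ring with a saturated ring, so the expectation here is poorly anchored. Compound 4 is estimated at 15 nM, range 3 nM to 80 nM. That estimate corresponds to an expected step of a 2.3-fold higher number from compound 3 to compound 4 (0.36 log units; beyond the scatter).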

Compound 4, half-maximal inhibitory concentration: 28 nM
For compound 4 the middle estimate is 1.9-fold (0.27 log units) below the measured one, within the range that was stated.
By their numbers in this assay, from the lowest: compounds 2, 1 and 3 (each within the scatter of the next); then compound 4.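

In this assay, replacing an aryl group with cyclohexyl on the sulfonyl sulfur gives the series its first steps beyond the scatter (a 4.2-fold higher number from compound 3 to compound 4 (0.63 log units; beyond the scatter); an 8.5-fold higher number from compound 2 to compound 4 (0.93 log units; beyond the scatter); a 7.0-fold higher number from compound 1 to compound 4 (0.85 log units; beyond the scatter)). Compounds 1, 2 and 3 stay within the scatter of one another, and compound 4 stands apart from all three, so this position tolerates exchange among these aryl groups better than the change to cyclohexyl. Nothing available accounts for this loss. Going by these compounds, whether a pyridyl, a cyclopentyl or a piperidinyl group on the sulfonyl sulfur would fall with compounds 1, 2 and 3 or with compound 4 remains open.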